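This account rests on a few compounds, and the source may have more. Where it says the series, first, only, none or still open, it means among the compounds named here.

Series notes. Compound 1 `Fc1ccc(-c2nn3c(NC4CCCC4)cccc3c2-c2ccnc(NC3CCCC3)n2)cc1` has no numerical read-out in an ADME assay on Vero cells (Chlorocebus sabaeus) for cytotoxicity; on this read-out lower numbers stand for higher toxicity in this test and higher numbers for lower toxicity in this test; the value > 160000 nM for compound 1 is a limit of the assay, as noted by the limit of > 160000 nM in this assay, at which 1 of the 3 values shown sits. Compound 2 `Fc1ccc(-c2nn3c(N4CCCCC4)nccc3c2-c2ccnc(NC3CCCC3)n2)cc1` likewise reaches only a limit, with > 40000 nM in this assay, as noted by the limit of > 40000 nM in this assay, at which 1 of the 3 values shown sits. Among the measured compounds shown here, compound 3 `Oc1ccc(-c2nn3c(NC4CCCC4)nccc3c2-c2ccnc(NC3CCCC3)n2)cc1` gives 27000 nM in this assay, the only finite number among the three, and the sole fixed point for what follows.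

Compound 4 `c1cc(-c2c(-c3ccc(OCC4CC4)cc3)nn3c(NC4CCCC4)nccc23)nc(NC2CCCC2)n1` is not yet measured in this assay. Against compound 3 it carries cyclopropylmethyl in place of hydrogen on an oxygen on an aromatic ring, that is cyclopropylmethyl in place of hydrogen on an oxygen on an aromatic ring, so that the hydroxy group of compound 3 becomes a cyclopropylmethoxy group. No step between two measured compounds of the series speaks to this kind of change, and no cause for any difference can be given from the data shown.

The expectation for compound 4 is therefore a modest step in this assay, a 1.4-fold lower number from compound 3 to compound 4 (0.13 log units; within the scatter), towards a slightly lower value without clearing the scatter with confidence. The estimate for compound 4 in this assay is 20000 nM, expected between 8000 nM and 50000 nM.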

Compound 4, half-maximal cytotoxic concentration: > 40000 nM
Compound 4: only a limit was reported (the forecaster's own chance of this, stated with the estimate: 20%); at least 2.0-fold (0.30 log units) between middle value and limit.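

On an oxygen on an aromatic ring, hydroxy to cyclopropylmethoxy gives the series its first step in this assay: an at least 1.4-fold higher number from compound 3 to compound 4 (0.17 log units; that floor lies within the scatter). Among the compounds shown here, the change therefore brings no lower number in this test at this place, which the earlier compounds, with no step among them, could not show. Compound 4 reports only a limit, so the step has a floor and no measured size: the limit of > 40000 nM in this assay, at which 2 of the 4 values shown sit.

How far the true value of compound 4 lies from that limit remains open, and the data give no cause for the step. Also open, as far as these compounds go, is whether a methyl group, a longer alkyl chain or a chain ending in an amine on the same oxygen would give a finite number in this assay.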